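A few compounds are considered here, and "the series" means these few. Any claim that something is new, unique, unknown or untested is made for them only; others in the source may bear on it.

The compounds in this set share a core and carry a benzamide bearing an aminophenyl group, and three of them have been measured in a functional assay on HepG2 cells (Homo sapiens) for antiproliferative activity, read by CCK-8 assay, with a stated time of 72 h, tested at 8 uM; on this read-out higher numbers stand for a stronger effect at the one concentration tested and lower numbers for a weaker effect. Compound 1, `CCCCn1cnc2c(Nc3cccc(Cl)c3)nc(NCOCc3ccc(/C=C/C(=O)Nc4ccccc4N)cc3)nc21`, gives 30.4% in this assay. Compound 3, `CC1CCN(c2nc(Cl)nc3c2ncn3Cc2ccc(/C=C/C(=O)Nc3ccccc3N)cc2)CC1`, gives 32.2%. Compound 2, `Cc1ccc(Nc2nc(Cl)nc3c2ncn3Cc2ccc(C(=O)Nc3ccccc3N)cc2)cc1`, gives 82%, the highest of the three numbers; its gaps to compound 3 and to compound 1 both lie beyond the scatter of repeated measurements of this kind, so compound 2 stands as the strongest of the measured set.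

Compound 4, `Nc1ccccc1NC(=O)c1ccc(Cn2cnc3c(Nc4cccc(OC(F)(F)F)c4)nc(Cl)nc32)cc1`, has not yet been measured. It differs from compound 2 in one place: 3-(trifluoromethoxy)phenyl in place of 4-methylphenyl on a nitrogen on an aromatic ring. Among the measured compounds shown here, no pair of measured compounds differs in just this way, so the measured numbers do not show how such an exchange at this nitrogen moves the read-out. Compound 1 and compound 3 are lower than compound 2, but each differs from it at several places at once and says nothing about this exchange alone. The expected step is a number 14 percentage points lower from compound 2 to compound 4 (beyond the scatter), a modest decrease in this assay that may well fall within the scatter. Compound 4 is estimated to give 68% in this assay, within a range from 40% to 90%.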

Compound 4, a percentage reported as inhibition, at one concentration (the size of the read-out at that concentration, not a potency): 31.2%
Compound 4: middle estimate off by 36.8 percentage points, on the high side, and the stated range ends above it.
By their numbers in this assay, from the lowest: compounds 1, 4 and 3 (each within the scatter of the next); then compound 2.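

In this assay, among the compounds shown here, 3-(trifluoromethoxy)phenyl in place of 4-methylphenyl on a nitrogen on an aromatic ring gives a number 50.8 percentage points lower from compound 2 to compound 4 (beyond the scatter), and this large step is the only exchange in the set that can be read at a single place, showing that the read-out depends strongly on the group carried by this nitrogen. The step still joins several differences in one exchange: the substituent on the phenyl ring, where it sits on that ring, and the oxygen and fluorine atoms that enter, so it cannot assign the loss to any one of them. Nothing shown here accounts for the size of this step.

The compounds shown leave open whether plain phenyl, 3-methylphenyl or 4-(trifluoromethoxy)phenyl on this nitrogen would stay with 4-methylphenyl or fall with 3-(trifluoromethoxy)phenyl, which would separate the effect of the substituent from that of its place on the ring. For the compounds shown here, they also leave open whether the same exchange would move the read-out by a similar amount on another compound in the set, since it is seen here in only one pair.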